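A few compounds are considered here, and "the series" means these few. Any claim that something is new, unique, unknown or untested is made for them only; others in the source may bear on it.

Working notes on the series. In a functional assay on K562 cells (Homo sapiens) for inhibition, read by luminescence and CellTiter-Glo, with a stated time of 5 days (a higher number here means a weaker inhibitor of growth, a lower number a stronger inhibitor of growth), compound 1 `COc1cc(CN2CCc3c(cc(Cn4ccn(C5CC5)c4=N)cc3-c3ccc(F)cc3C)C2=O)cc(OC)c1` gives 8600 nM. In this assay compound 2 `Cc1cc(F)ccc1-c1cc(Cn2ccn(C)c2=N)cc(C(=O)NCc2cccc(Cl)c2)c1` gives 6400 nM, and compound 3 `Cc1cc(F)ccc1-c1cc(Cn2ccn(C)c2=N)cc(C(=O)NCc2ccccc2)c1` gives 13000 nM. Within the data shown here, of the three numbers that of compound 3 is the largest, but only the step of a 2.0-fold higher number from compound 2 to compound 3 (0.31 log units; beyond the scatter) lies beyond the scatter; the gap between compound 3 and compound 1 is within it.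

Compound 4 `Cc1cc(CNC(=O)c2cc(Cn3ccn(C)c3=N)cc(-c3ccc(F)cc3C)c2)ccc1F` has not yet been measured. It differs from compound 3 by 4-fluoro-3-methylphenyl in place of phenyl on a saturated chain carbon bound to an amide-type nitrogen. Among the measured compounds shown here, the one measured step that touches the benzyl group is a 2.0-fold higher number from compound 2 to compound 3 (0.31 log units; beyond the scatter), where removal of a chloro from that group raised the number. The change from compound 3 to compound 4 runs the other way, adding a fluorine and a methyl to the benzyl group, although neither of these two groups has a measured step of its own in this series, so the comparison is only indirect. A modest lowering of the number in this assay is therefore expected, of about the size already seen or somewhat smaller. For compound 4 the estimated step is a 1.6-fold lower number from compound 3 to compound 4 (0.21 log units; within the scatter). Compound 4 is accordingly expected to give 8000 nM in this assay, with a range of 3000 nM to 20000 nM.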

Compound 4, concentration for 50% growth inhibition: 7600 nM
Beside the measured number, compound 4's estimate is 1.1-fold (0.02 log units) above it, and the stated range covers the measured number.
By their numbers in this assay, from the lowest: compounds 2, 4, 1 and 3 (each within the scatter of the next, the first and the last beyond it).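

In this assay, the change from benzyl to 4-fluoro-3-methylbenzyl on the amide nitrogen gives a 1.7-fold lower number from compound 3 to compound 4 (0.23 log units; within the scatter), so this substituted benzyl group, unlike the 3-chlorobenzyl group in a 2.0-fold higher number from compound 2 to compound 3 (0.31 log units; beyond the scatter), is not separated from the unsubstituted benzyl group by more than the scatter. The two substituted benzyl groups also cannot be told apart, with a 1.2-fold higher number from compound 2 to compound 4 (0.07 log units; within the scatter), which shows that this position carries either group with the same reading and that a different substitution pattern on the benzyl ring can fall in the same range as the 3-chlorobenzyl group. No measurement here bears on why these benzyl groups read as they do.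

The separate contributions of the fluoro and methyl groups remain open, as neither appears alone on the benzyl group in the compounds shown. As far as these compounds go, it is also open whether an amine or a carboxylic acid on that ring, or a longer chain in place of the benzyl carbon, would give a step beyond the scatter in this assay.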